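Adding a Chloro Group to Compound 1

This account rests on a few compounds, and the source may have more. Where it says the series, first, only, none or still open, it means among the compounds named here.

Of the compounds shown here, three sharing one core have been measured in a functional assay on HUVEC cells (Homo sapiens) for inhibition, read by MTT assay, with a stated time of 24 h, tested at 100 uM; a higher number here means more inhibition of growth at the concentration tested, a lower number less inhibition of growth. Compound 1 `COc1cc2ccc(=O)oc2cc1OCC(=O)c1ccccc1` gives 83.6%, the highest of the three numbers. Compound 2 `COc1cc2ccc(=O)oc2cc1OCC(O)CN1CCCC1` gives 0.3%, and compound 3 `COc1cc2ccc(=O)oc2cc1OCC(O)CNC(C)C` gives 6.3%, so compound 1 stands beyond the scatter above both of them. Going by the values given here, the only measured step within the set, a number 6 percentage points higher from compound 2 to compound 3 (within the scatter), concerns these two weaker compounds and lies within the scatter.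

Compound 4 `COc1cc2ccc(=O)oc2cc1OCC(=O)c1ccc(Cl)cc1` differs from compound 1 in one place: chloro in place of hydrogen on an aromatic carbon. Among the compounds with values here, no measured pair in this assay bears on this change; the step from compound 2 to compound 3 touches a different part of the molecule and carries no information about a substituent on the aromatic ring. With nothing to point either way, and with compound 1 already giving 83.6% in this assay, the expected step in this assay is none beyond the scatter. Compound 4 is therefore estimated at 82%, with a range of 65% to 95%. The step this estimate implies, a number 1.6 percentage points lower from compound 1 to compound 4 (within the scatter), is expected to be small.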

Compound 4, percent growth inhibition at one concentration: 83.8%
For compound 4 the middle estimate is 1.8 percentage points below the measured one, and the stated range covers the measured number.
By their numbers in this assay, from the lowest: compounds 2 and 3 (each within the scatter of the next); then compounds 1 and 4 (each within the scatter of the next).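

In this assay, going by these compounds alone, the change from phenyl to 4-chlorophenyl gives a number 0.2 percentage points higher from compound 1 to compound 4 (within the scatter) and is the first measured change on this aromatic ring, since the earlier step concerned only the amine at the end of the saturated chain. It shows that a single chlorine on this carbon, para to a large group, leaves the reading of compound 4 level with that of compound 1 at this one tested concentration, so a heavy atom can stand at this position without a measurable loss of growth inhibition. No available evidence explains why the reading stays level, and none bears on this result.

From the compounds shown here alone, whether a methoxy group, an amine or a carboxylic acid on the same carbon would also leave the reading level remains open, as does the effect of a chloro group on another carbon of this ring. Since both compounds were read at a single concentration, the compounds shown also leave open whether compound 1 and compound 4 would stay level at lower concentrations.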